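Swapping an amide linker for a sulfonamide linker

A few compounds are considered here, and "the series" means these few. Any claim that something is new, unique, unknown or untested is made for them only; others in the source may bear on it.

Measured so far in a functional assay on 143B cells (Homo sapiens) for antiproliferative activity, read by MTT assay, with a stated time of 48 h; on this read-out higher numbers stand for weaker inhibition and lower numbers for stronger inhibition:
- compound 1 `O=C(Nc1cccc(/C=C/C(=O)c2nc3ccccc3[nH]2)c1)c1cccc(Cl)c1`: 3370 nM
- compound 2 `COc1cccc(C(=O)Nc2cccc(/C=C/C(=O)c3nc4ccccc4[nH]3)c2)c1`: 4610 nM

Within the data shown here, compound 2 gives the highest of the two numbers in this assay, but its only neighbour is compound 1, and the step of a 1.4-fold higher number from compound 1 to compound 2 (0.14 log units; within the scatter) is within the scatter, so the two compounds cannot be told apart on these data.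

Compound 3 `O=C(/C=C/c1cccc(NS(=O)(=O)c2cccc(Cl)c2)c1)c1nc2ccccc2[nH]1` is built from compound 2 by a change at the amide nitrogen: (3-chlorophenyl)sulfonyl in place of (3-methoxyphenyl)carbonyl on a nitrogen on an aromatic ring. This replaces the whole linker group, not just a substituent on it. Among the measured compounds shown here, none of the measured steps covers such a change; the one step on record, a 1.4-fold higher number from compound 1 to compound 2 (0.14 log units; within the scatter), only compares methoxy with chloro on the outer ring and lies within the scatter, which at most suggests that the chloro part of the incoming group need not by itself shift the number. For the measured compounds named here, for the carbonyl-to-sulfonyl exchange there is no precedent here, so the expectation rests on compound 2 alone with wide uncertainty.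

Compound 3 is therefore expected to come out near compound 2, with a step of a 1.2-fold lower number from compound 2 to compound 3 (0.06 log units; within the scatter), giving an estimated 4000 nM in this assay, within a range of 1200 nM to 13000 nM.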

Compound 3, half-maximal inhibitory concentration: 2510 nM
For compound 3 the middle estimate is 1.6-fold (0.20 log units) above the measured one; measured number inside the range.
By their numbers in this assay, from the lowest: compounds 3, 1 and 2 (each within the scatter of the next).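

The clearest reading of the linker swap comes from the pair that keeps the same 3-chlorophenyl outer ring. In this pair only carbonyl changes to sulfonyl on the nitrogen on an aromatic ring: in this assay this gives (a 1.3-fold lower number from compound 1 to compound 3 (0.13 log units; within the scatter)), which is within the scatter. The second comparison changes the linker and the outer-ring substituent together, and it also stays within the scatter (a 1.8-fold lower number from compound 2 to compound 3 (0.26 log units; within the scatter)). Across these compounds, then, sulfonyl can replace carbonyl at this nitrogen without a difference that can be told from repeat-measurement noise, something the earlier chloro-to-methoxy comparison could not show, though no measurement here offers an explanation for this result.

The three compounds leave open whether this tolerance extends to a urea or a methylene linker on the same nitrogen, which would test groups other than carbonyl and sulfonyl. Going by these compounds, it also remains open how the sulfonyl series responds to a different outer-ring substituent, such as an amine or a carboxylic acid, since only chloro has been seen there.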